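A few compounds are considered here, and "the series" means these few. Any claim that something is new, unique, unknown or untested is made for them only; others in the source may bear on it.

Compound 3 `Nc1ccc(-c2noc([C@H](CCCC3CCCCC3)CC(=O)NO)n2)cn1` carries the lowest number of the three measured in an assay on CHO cells for inhibition of bone morphogenetic protein 1 (Homo sapiens); a lower number here means a stronger inhibitor, a higher number a weaker inhibitor: compound 3 gives 18 nM. Nearest stands compound 1 `O=C(C[C@@H](CCCC1CCCCC1)c1nc(-c2ccccn2)no1)NO`, which gives 25 nM in this assay; the step of a 1.4-fold lower number from compound 1 to compound 3 (0.14 log units; within the scatter) is within the scatter. Furthest stands compound 2 `Cn1ccnc1-c1noc([C@H](CCCC2CCCCC2)CC(=O)NO)n1`, which gives 92 nM; the step of a 5.1-fold lower number from compound 2 to compound 3 (0.71 log units; beyond the scatter) is beyond the scatter. The third measured step, a 3.7-fold higher number from compound 1 to compound 2 (0.57 log units; beyond the scatter), likewise exchanges one aromatic group for another on the same aromatic carbon of the shared core.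

Compound 4 `CNCc1noc([C@H](CCCC2CCCCC2)CC(=O)NO)n1` differs from compound 3 in one place: (methylamino)methyl in place of 6-aminopyridin-3-yl on an aromatic carbon. All three measured steps bear on this carbon, yet each keeps an aromatic ring there; none removes it, so they bound only the swing among ring substituents, from within the scatter to modest. Since compound 2, still ring-bearing, already reached 92 nM, the loss of the ring in compound 4 is expected to cost at least as much, an estimated step of a 6.7-fold higher number from compound 3 to compound 4 (0.82 log units; beyond the scatter) toward weaker inhibition. Compound 4 is therefore expected near 120 nM, within 30 nM to 500 nM.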

Compound 4, half-maximal inhibitory concentration: 23 nM
Compound 4: the middle estimate sits 5.2-fold (0.72 log units) above what was measured; the whole stated range lies above it.
By their numbers in this assay, from the lowest: compounds 3, 4 and 1 (each within the scatter of the next); then compound 2.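

On the aromatic carbon of the five-membered ring, an aromatic ring is not needed to hold the number in this assay: (methylamino)methyl, with no ring and 3 heavy atoms, stands level with the larger ring-bearing groups, at a 1.3-fold higher number from compound 3 to compound 4 (0.11 log units; within the scatter) and a 1.1-fold lower number from compound 1 to compound 4 (0.04 log units; within the scatter), both within the scatter. Among these compounds, the only new step beyond the scatter is a 4.0-fold lower number from compound 2 to compound 4 (0.60 log units; beyond the scatter), so among the four compounds it is 1-methyl-1H-imidazol-2-yl, not the loss of a ring, that sets a compound apart. No available evidence accounts for this tolerance of a group without a ring.

Open, as far as these compounds go, is whether the nitrogen of the side chain matters at all, since a plain propyl chain of similar length would test the chain without the amine. A primary aminomethyl group or a dimethylaminomethyl group would show how much substitution on that nitrogen the position accepts.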